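Methoxy placement on the benzoyl ring of aminothiazole ketones

The source may hold more compounds than are shown below. What is called first, only, known or untested is meant among the compounds shown, and "the series" means these compounds.

Measured so far:
compound 1 `COc1cc(C(=O)c2sc(Nc3ccccc3)nc2N)cc(OC)c1OC` gives 6 nM in a functional assay on MOLT-4 cells (Homo sapiens) for antiproliferative activity, read by cell counting, with a stated time of 2 days; on this read-out higher numbers stand for weaker inhibition and lower numbers for stronger inhibition
compound 2 `COc1ccc(C(=O)c2sc(Nc3ccccc3)nc2N)cc1OC` gives 5500 nM in this assay
compound 3 `Nc1nc(Nc2ccc(F)cc2)sc1C(=O)c1ccccc1` gives > 10000 nM in this assay

The value of compound 3 is a limit of the assay, not a number, as seen in the limit of > 10000 nM in this assay, at which 1 of the 3 values shown sits.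

Compound 4 `COc1ccc(C(=O)c2sc(Nc3ccc(F)cc3)nc2N)cc1` is not yet measured. The change from compound 2 to compound 1 is methoxy in place of hydrogen on an aromatic carbon and it made a step of a 920-fold lower number from compound 2 to compound 1 (2.96 log units; beyond the scatter). The change from compound 3 to compound 4 is methoxy in place of hydrogen on an aromatic carbon: the same kind of change, but the place is not the same, being para to a large group rather than ortho to a methoxy group, meta to a large group and meta to a methoxy group. The difference between the two cores is not broken down here.

For the measured compounds named here, for compound 4 a step of an at least 1.6-fold lower number from compound 3 to compound 4 (0.22 log units; that floor lies within the scatter) is expected, since compound 3 offers only a limit and only one measured step of this kind exists. Compound 4 is estimated at 6000 nM, between 1000 nM and 30000 nM.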

Compound 4, half-maximal inhibitory concentration: > 10000 nM
Compound 4 ended at the assay's limit; the forecaster's own chance of this, stated with the estimate: 40%; at least 1.6-fold (0.22 log units) between middle value and limit.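

The values of compound 3 and compound 4 in this assay are both limits, not numbers, so no step between them can be read: the limit of > 10000 nM in this assay, at which 2 of the 4 values shown sit.

The compounds shown leave open what phenyl to 4-methoxyphenyl does on this core.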